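Extending the hexyl chain of compound 2

The source may report more compounds than this note shows. Statements on the series, on what has been measured and on what is new or still open speak of the compounds shown alone.

In a functional assay, read by spectrophotometry, with a stated time of 6 min (on this read-out lower numbers stand for stronger inhibition and higher numbers for weaker inhibition), compound 1 (`COc1cc(O)c(C(C)=O)cc1Br`) gives 31400000 nM and compound 2 (`CCCCCCOc1cc(OC)c(Br)cc1C(C)=O`) gives 35700000 nM with no real separation between them. Among the compounds with values here, the only measured step (a 1.1-fold higher number from compound 1 to compound 2 (0.06 log units; within the scatter)) put hexyl in place of hydrogen on an oxygen on an aromatic ring and stayed within the scatter, so compound 2 stands level with compound 1. Compound 3 (`CCCCCCCCCCOc1cc(OC)c(Br)cc1C(C)=O`) differs from compound 2 by butyl in place of hydrogen on a saturated chain carbon, six bonds along the chain from an oxygen on an aromatic ring in that same chain. This single precedent is thin, yet no step beyond the scatter is expected in this assay for this change. The estimated step (a 1.2-fold lower number from compound 2 to compound 3 (0.08 log units; within the scatter)) is expected to stay within the scatter. For compound 3 the estimate is 30000000 nM with an expected range from 10000000 nM to 65000000 nM on this read-out.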

Compound 3, half-maximal inhibitory concentration: 34700000 nM
Compound 3: middle estimate off by 1.2-fold (0.06 log units), on the low side; the range from low to high includes it.
By their numbers in this assay, from the lowest: compounds 1, 3 and 2 (each within the scatter of the next).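

In this assay the added butyl gives a 1.0-fold lower number from compound 2 to compound 3 (0.01 log units; within the scatter), so this position on the chain takes the change without a step beyond the scatter. Compounds 1, 2 and 3 now form two consecutive steps on the same oxygen substituent, hexyl and then butyl, and both stay within the scatter. Nothing available gives a reason for this flat result.

On these data alone, whether a longer chain, or a chain ending in an amine or a carboxylic acid, would separate from compound 3 stays open. Also open, as far as these compounds go, is whether a change on the shared core would move the number in this assay.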